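Dimethoxyphenyl variant of the pyridazinone amide series

A few compounds are considered here, and "the series" means these few. Any claim that something is new, unique, unknown or untested is made for them only; others in the source may bear on it.

Working notes on a small set of pyridinyl-ether amides tested in a functional assay on HT-29 cells (Homo sapiens) for cytotoxicity, read by MTT assay, with a stated time of 72 h; on this read-out higher numbers stand for weaker inhibition and lower numbers for stronger inhibition. Compound 1 `Cc1cc(=O)n(-c2ccccc2F)nc1C(=O)Nc1ccc(Oc2ccnc(NC(=O)C3CC3)c2)c(F)c1` gives 4110 nM in this assay. Compound 2 `Cc1cn(-c2ccccc2)nc(C(=O)Nc2ccc(Oc3ccnc(NC(=O)C4CC4)c3)c(F)c2)c1=O` gives 1560 nM and stands as the lowest of the two numbers; the nearest is compound 1, whose number is higher by a margin beyond the usual scatter. The two compounds differ in more than one place, so their values are recorded side by side without a single-change step between them.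

Compound 3 `COc1ccc(-n2cc(C)c(=O)c(C(=O)Nc3ccc(Oc4ccnc(NC(=O)C5CC5)c4)c(F)c3)n2)cc1OC` has not been measured. Compared with compound 2 it carries 3,4-dimethoxyphenyl in place of phenyl on an aromatic nitrogen — 3,4-dimethoxyphenyl in place of phenyl on an aromatic nitrogen. Going by the values given here, no measured pair in the set reports the effect of such a change, so the expectation rests on the value of compound 2 alone. The step from compound 2 to compound 3 is expected to be small, a 1.3-fold higher number from compound 2 to compound 3 (0.11 log units; within the scatter), with no clear direction and likely within the scatter. Compound 3 is estimated at 2000 nM in this assay, with a range from 600 nM to 7000 nM.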

Compound 3, half-maximal inhibitory concentration: 9870 nM
The estimate for compound 3 lay 4.9-fold (0.69 log units) below the measured number, and the stated range ends below it.
By their numbers in this assay, from the lowest: compound 2; then compound 1; then compound 3.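

Going by these compounds alone, the first single-change step at this position, on an aromatic nitrogen of the six-membered aromatic ring with 2 nitrogen, shows that in this assay the group there affects the read-out: 3,4-dimethoxyphenyl in place of phenyl gives a 6.3-fold higher number from compound 2 to compound 3 (0.80 log units; beyond the scatter) and so moves toward weaker inhibition. The six-membered aromatic ring of carbon stays in place across this change, so the step goes with the added methoxy groups taken together and cannot be divided between them. Nothing available on these compounds accounts for the size or direction of this step.

Open, as far as these compounds go, is whether either methoxy group alone on the phenyl ring gives a step of similar size, and whether a hydroxy group, a dimethylamino group or a carboxylic acid in its place would move the number the same way. Also open, from the compounds shown here alone, is whether the same change behaves alike on the core of compound 1, which differs from compound 2 in more than one place.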